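Trading 4,4-difluorocyclohexyl for 1,1-dimethylpropyl on a carbonyl carbon

A few compounds are considered here, and "the series" means these few. Any claim that something is new, unique, unknown or untested is made for them only; others in the source may bear on it.

Of the compounds shown here, three on a shared core have been read in a functional assay on NCI-H460 cells (Homo sapiens) for cytotoxicity, read by MTT assay, with a stated time of 48 h; on this read-out higher numbers stand for weaker inhibition and lower numbers for stronger inhibition. Compound 1 `C=C1C(=O)O[C@H]2CC3=C[C@H](C/C(C)=C/[C@@H](OC(=O)c4ccc(C(C)=O)cc4)[C@H]12)OC3=O`, carrying 4-acetylphenyl on a carbonyl carbon, gives 2200 nM. Compound 2 `C=C1C(=O)O[C@H]2CC3=C[C@H](C/C(C)=C/[C@@H](OC(=O)CCCCC)[C@H]12)OC3=O`, carrying pentyl there, gives 5900 nM. Compound 3 `C=C1C(=O)O[C@H]2CC3=C[C@H](C/C(C)=C/[C@@H](OC(=O)C4CCC(F)(F)CC4)[C@H]12)OC3=O`, carrying 4,4-difluorocyclohexyl, gives > 10000 nM, which is a limit and not a number, so it stands without a measured value. Compound 4 `C=C1C(=O)O[C@H]2CC3=C[C@H](C/C(C)=C/[C@@H](OC(=O)C(C)(C)CC)[C@H]12)OC3=O` changes that group: 1,1-dimethylpropyl in place of 4,4-difluorocyclohexyl on a carbonyl carbon. The entering group has no ring, like the pentyl of compound 2.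

The closest measured comparison is an at least 1.6-fold higher number from compound 2 to compound 3 (0.22 log units; that floor lies within the scatter). The other two comparisons are a 2.7-fold higher number from compound 1 to compound 2 (0.43 log units; beyond the scatter) and an at least 4.5-fold higher number from compound 1 to compound 3 (0.65 log units; beyond the scatter), which set both groups against 4-acetylphenyl. A modest move towards a lower number is expected because compound 2 gave 5900 nM with an open chain. The expected change is an at least 1.5-fold lower number from compound 3 to compound 4 (0.18 log units; that floor lies within the scatter). For compound 4 the estimate is 6500 nM, with an expected range from 2800 nM to 15000 nM.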

Compound 4, half-maximal inhibitory concentration: 6100 nM
The estimate for compound 4 lay 1.1-fold (0.03 log units) above the measured number, within the range that was stated.
By their numbers in this assay, from the lowest: compound 1; then compounds 2 and 4 (each within the scatter of the next). At a limit, above all of these: compound 3.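

In this assay, setting 1,1-dimethylpropyl against pentyl on this carbonyl carbon gives a 1.0-fold higher number from compound 2 to compound 4 (0.01 log units; within the scatter), so these two open chains, which differ in shape, cannot be told apart here. Set against 4-acetylphenyl, 1,1-dimethylpropyl gives a 2.8-fold higher number from compound 1 to compound 4 (0.44 log units; beyond the scatter), the same distance from compound 1 that pentyl showed, and the aromatic group of compound 1 remains apart from both chains. Replacing 4,4-difluorocyclohexyl gives an at least 1.6-fold lower number from compound 3 to compound 4 (0.21 log units; that floor lies within the scatter), and compound 3 stands at a limit, so this step offers only a floor and does not show how far the ring group lies from the open chains: the limit of > 10000 nM in this assay, at which 1 of the 4 values shown sits.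

On these data alone, whether the fluorines or the ring itself matter in compound 3 stays open, and plain cyclohexyl would separate the two. Also open, as far as these compounds go, is whether the acetyl group matters in compound 1, which plain phenyl or a phenyl ring carrying a carboxylic acid or an amine would address.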